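Solubility across a pyrazolopyridine-free naming: the series in buffer

This account rests on a few compounds, and the source may have more. Where it says the series, first, only, none or still open, it means among the compounds named here.

Measured so far:
compound 1 `CCc1ccc(-c2nc3c(c(C)nn3-c3ccccc3)c(-c3ccccc3Br)c2C#N)cc1`: 1500 nM
compound 2 `CCc1ccc(-c2nc3c(c(C)nn3-c3ccccc3)c(-c3ccccc3)c2C#N)cc1`: 47000 nM

In a physicochemical assay for solubility, read by spectrophotometry, in phosphate buffer, with a stated time of 18 h, at pH 7.4 (a lower number here means a less soluble compound, a higher number a more soluble compound), compound 1 gives 1500 nM, the lowest of the two numbers; compound 2 gives 47000 nM. Within the data shown here, the one measured step, a 31-fold higher number from compound 1 to compound 2 (1.50 log units; beyond the scatter), bears directly on the change here. Compound 3 `CCc1ccc(-c2nc3c(c(C)nn3-c3ccccc3)c(-c3ccc(O)cc3)c2C#N)cc1` differs from compound 1 as follows: 4-hydroxyphenyl in place of 2-bromophenyl on an aromatic carbon. Since the bromo leaves again, a step of similar size and direction is expected, so compound 3 is estimated at 60000 nM, range 15000 nM to 250000 nM, meaning an expected 40-fold higher number from compound 1 to compound 3 (1.60 log units; beyond the scatter).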

Compound 3, solubility: 5700 nM
Compound 3: middle estimate off by 11-fold (1.02 log units), on the high side, outside the stated range (below it).
By their numbers in this assay, from the lowest: compound 1; then compound 3; then compound 2.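

In this assay the aryl group opposite the ring nitrogen shifts the number in both directions: hydroxy in place of hydrogen goes with an 8.2-fold lower number from compound 2 to compound 3 (0.92 log units; beyond the scatter) and 4-hydroxyphenyl in place of 2-bromophenyl goes with a 3.8-fold higher number from compound 1 to compound 3 (0.58 log units; beyond the scatter). Loss of the bromo therefore does not set the number alone, and the plain phenyl of compound 2 stays highest of the three. No measurement at hand accounts for these steps. Open, on these data alone, is whether a methoxy or an amine in place of the hydroxy of compound 3 would give a similar number.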